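Cytotoxicity notes on a dichlorobenzyl thiopyrimidinone series

A few compounds are considered here, and "the series" means these few. Any claim that something is new, unique, unknown or untested is made for them only; others in the source may bear on it.

Measured so far, in an ADME assay on MT4 cells (Homo sapiens) for cytotoxicity, read by MTT assay; on this read-out higher numbers stand for lower toxicity in this test and lower numbers for higher toxicity in this test:
compound 1, `Cc1c(Cc2c(Cl)cccc2Cl)nc(SCC(=O)c2ccc(F)cc2)[nH]c1=O`: compound 1 gives > 57000 nM, a limit of the assay.
compound 2, `COc1ccc(C(=O)CSc2nc(Cc3c(Cl)cccc3Cl)c(C)c(=O)[nH]2)cc1`: compound 2 gives > 56000 nM, a limit of the assay.
compound 3, `CC(C)c1c(Cc2c(Cl)cccc2Cl)nc(SCC(=O)c2ccc(F)cc2)[nH]c1=O`: compound 3 gives > 54000 nM, a limit of the assay.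

For the measured compounds named here, all three values sit at the top of the tested range: the limit of > 57000 nM in this assay, at which 1 of the 3 values shown sits, the limit of > 56000 nM in this assay, at which 1 of the 3 values shown sits, and the limit of > 54000 nM in this assay, at which 1 of the 3 values shown sits, describe the whole picture in this assay so far. The change from compound 1 to compound 2 is methoxy in place of fluoro on an aromatic carbon, and the step it made, a step that the two limits leave unreadable from compound 1 to compound 2, cannot be sized because both ends are limits. The two cores differ by isopropyl in place of methyl on an aromatic carbon, and here too the step that the two limits leave unreadable from compound 1 to compound 3 stays unreadable for the same reason.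

Compound 4, `COc1ccc(C(=O)CSc2nc(Cc3c(Cl)cccc3Cl)c(C(C)C)c(=O)[nH]2)cc1`, carries the same change on the core of compound 3: methoxy in place of fluoro on an aromatic carbon. The place is described in the same words for both pairs, so this is the same change, not merely the same kind. For the step from compound 3 to compound 4 in this assay the expectation is a step that the limit leaves unreadable from compound 3 to compound 4, resting on the unreadable step that the two limits leave unreadable from compound 1 to compound 2 and on the limit of compound 3, > 54000 nM. On that basis compound 4 is estimated at 60000 nM, most likely reported again only as a limit.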

Compound 4, half-maximal cytotoxic concentration: > 14000 nM
Compound 4 gave a limit, no number; the forecaster's own chance of this, stated with the estimate: 85%; the middle value lies beyond the limit too.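

In this assay compound 4 gives > 14000 nM, which is again a limit of the assay. The steps to compound 4 from compound 2 and compound 3 have limits at both ends and cannot be read. The compounds shown leave open where the actual cytotoxic concentration of each compound lies, and whether methoxy in place of fluoro or isopropyl in place of methyl changes it at all.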